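Two aryl groups end the activity; an ethenyl bridge next

The source may report more compounds than this note shows. Statements on the series, on what has been measured and on what is new or still open speak of the compounds shown alone.

Measured compounds:
- compound 1 `CCCC#Cc1cc([C@@H]2O[C@H](CO)[C@@H](O)[C@H]2O)n2ncnc(N)c12`: 1100 nM
- compound 2 `Nc1ncnn2c([C@@H]3O[C@H](CO)[C@@H](O)[C@H]3O)cc(-c3ccccc3)c12`: > 100000 nM
- compound 3 `Cc1ccccc1-c1cc([C@@H]2O[C@H](CO)[C@@H](O)[C@H]2O)n2ncnc(N)c12`: > 100000 nM

Among the measured compounds shown here, in a functional assay on K562 cells (Homo sapiens) for antiproliferative activity, with a stated time of 72 h (on this read-out lower numbers stand for stronger inhibition and higher numbers for weaker inhibition), compound 1 gives 1100 nM and is the only compound of the three with a number rather than a limit. Compound 2 reaches only a limit of this assay, > 100000 nM. Compound 3 likewise sits at a limit, > 100000 nM. The step of an at least 90-fold higher number from compound 1 to compound 2 (1.95 log units; beyond the scatter) and the step of an at least 90-fold higher number from compound 1 to compound 3 (1.95 log units; beyond the scatter) are both large and both lead to the limit of > 100000 nM in this assay, at which 2 of the 3 values shown sit; the step that the two limits leave unreadable from compound 2 to compound 3 cannot be sized.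

Compound 4 `Nc1ncnn2c([C@@H]3O[C@H](CO)[C@@H](O)[C@H]3O)cc(/C=C/c3ccccc3)c12` is not yet measured. It differs from compound 1 by 2-phenylethenyl in place of pent-1-yn-1-yl on an aromatic carbon. Both measured steps from compound 1 that bring a six-membered aromatic ring onto this position raise the number far beyond the scatter, so a large rise is expected for compound 4 as well, though the double bond keeps part of the extended shape of the pent-1-yn-1-yl chain, which may soften the loss. The expected step is an 18-fold higher number from compound 1 to compound 4 (1.26 log units; beyond the scatter). For compound 4 the estimate is 20000 nM, within 3000 nM to 150000 nM.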

Compound 4, half-maximal inhibitory concentration: 3100 nM
For compound 4 the middle estimate is 6.5-fold (0.81 log units) above the measured one; the measured number falls inside the stated range.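

The 2-phenylethenyl group also carries a six-membered aromatic ring, yet putting it in place of pent-1-yn-1-yl gives only a 2.8-fold higher number from compound 1 to compound 4 (0.45 log units; beyond the scatter), so such a ring at this position does not by itself end the activity in this assay. Among the ring-bearing groups, the double bond outside the aromatic ring marks the difference: 2-phenylethenyl in place of phenyl gives an at least 32-fold lower number from compound 2 to compound 4 (1.50 log units; beyond the scatter), and in place of 2-methylphenyl it gives an at least 32-fold lower number from compound 3 to compound 4 (1.50 log units; beyond the scatter). Both of these steps start from a limit rather than a number: the limit of > 100000 nM in this assay, at which 2 of the 4 values shown sit.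

On these data alone, it remains open whether 2-phenylethyl, with a saturated link to the same phenyl ring, keeps the activity of compound 4. Also open, as far as these compounds go, is how a longer chain such as hept-1-yn-1-yl, or a pent-1-yn-1-yl chain ending in an amine, compares with compound 1.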